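This account rests on a few compounds, and the source may have more. Where it says the series, first, only, none or still open, it means among the compounds named here.

Measured compounds:
compound 1, `Cc1ccccc1-n1cc(-c2cccc(NS(=O)(=O)c3c[nH]c(=O)[nH]c3=O)c2)nn1`, which in a functional assay on A549 cells (Homo sapiens) for antiproliferative activity, read by MTT assay, with a stated time of 24 h (a lower number here means a stronger inhibitor, a higher number a weaker inhibitor), gives 5470 nM
compound 2, `Cc1ccccc1-n1cc(-c2ccc(NS(=O)(=O)c3c[nH]c(=O)[nH]c3=O)cc2)nn1`, which in this assay gives 3130 nM

Compound 2 carries the lower of the two numbers, but its gap to compound 1 is within the usual scatter of this assay, so the two cannot be told apart on these data. Compound 3, `O=c1[nH]cc(S(=O)(=O)Nc2ccc(-c3cn(-c4cccc(F)c4)nn3)cc2)c(=O)[nH]1`, is the next step from compound 2. The change is 3-fluorophenyl in place of 2-methylphenyl on an aromatic nitrogen. No comparison of this kind between measured compounds is available, so the effect of the change is an open question. The step from compound 2 to compound 3 is expected to be small, in no particular direction, and to stay within the scatter, which is what a 1.0-fold higher number from compound 2 to compound 3 (0.01 log units; within the scatter) means. Compound 3 is therefore expected to give about 3200 nM in this assay, with a plausible range from 1100 nM to 9500 nM.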

Compound 3, half-maximal inhibitory concentration: 9980 nM
Compound 3: the middle estimate sits 3.1-fold (0.49 log units) below what was measured; measured number above the stated range.
By their numbers in this assay, from the lowest: compounds 2, 1 and 3 (each within the scatter of the next, the first and the last beyond it).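

In this assay the group on the aromatic nitrogen proves able to shift the number: 3-fluorophenyl in place of 2-methylphenyl brings a 3.2-fold higher number from compound 2 to compound 3 (0.50 log units; beyond the scatter) and so a modest loss of activity. The two groups have the same heavy-atom count and the same counts of hydrogen-bond donors and acceptors, so those counts alone do not account for the difference in activity. Nothing available here bears on the reason for this step.

This single step cannot separate the loss of the methyl group from the arrival of the fluorine, since both change at once. It also leaves open how this position would respond to an amine or a carboxylic acid on the phenyl ring, or to a longer chain in place of that ring.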